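This account rests on a few compounds, and the source may have more. Where it says the series, first, only, none or still open, it means among the compounds named here.

Of the compounds shown here, three have so far been measured in a functional assay on Umbilical vein for antagonist activity at B1 bradykinin receptor (Homo sapiens), using Schild analysis, with a stated time of 30 min; on this read-out higher numbers stand for higher potency (the scale is a negative logarithm) and lower numbers for lower potency. Compound 1 `COc1cc(C)c(S(=O)(=O)N(C)CCOCC(=O)N2CCN(C3CCN(C4CC4)CC3)CC2)c(C)c1` gives 8.5 in this assay. Compound 2 `CN(Cc1ccc(C2=NCCN2)cc1)C(=O)COCCN(C)S(=O)(=O)c1ccccc1C(F)(F)F` gives 9.2, and compound 3 `COc1cc(C)c(S(=O)(=O)N(C)CCOCC(=O)N2CCC(C(O)CN(C)C)CC2)c(C)c1` gives 7.4. Compound 1 therefore stands second of the three: compound 2 lies higher by a step beyond the scatter, and compound 3 lies lower by a wider step, also beyond the scatter. No pair among these three differs in only one place, so no single structural step can be read from the measured numbers themselves.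

Compound 4 `COc1cc(C)c(S(=O)(=O)N(C)CCOCC(=O)N2CCN(CCN(C)C)CC2)c(C)c1` has not yet been measured. It differs from compound 1 in one place: 2-(dimethylamino)ethyl in place of 1-cyclopropylpiperidin-4-yl on an amine nitrogen in a ring. Going by the values given here, the only guide is compound 3, which shares the core of compound 1 and ends its side chain in a different way; compound 3 gives 7.4, a lower number. The step of a number 0.50 log units lower from compound 1 to compound 4 (beyond the scatter) is expected to be a modest loss, close to the edge of the scatter. Compound 4 is accordingly estimated at 8, with a range from 7.3 to 8.7.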

Compound 4, negative logarithm of the antagonist equilibrium constant: 7.4
The estimate for compound 4 lay 0.60 log units above the measured number, within the range that was stated.
By their numbers in this assay, from the lowest: compounds 3 and 4 (each within the scatter of the next); then compound 1; then compound 2.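

In this assay, going by these compounds alone, the group on this amine nitrogen in a ring of the core of compound 1 proves to matter: replacing 1-cyclopropylpiperidin-4-yl with 2-(dimethylamino)ethyl gives a number 1.10 log units lower from compound 1 to compound 4 (beyond the scatter) and this large drop is the first single-place step that can be read from measured numbers. The change removes both rings of the leaving group and lowers the heavy-atom count, while the counts of hydrogen-bond donors and acceptors stay the same. Nothing available explains why the number falls.

On these data alone, the three-membered ring and the six-membered ring leave together in this one change, so how much of the step belongs to each remains open. Also open, as far as these compounds go, is how a 1-methylpiperidin-4-yl group, or a longer chain ending in dimethylamino, would stand on this nitrogen.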